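The compounds below may be only part of what the source reports. "The series", "measured", "known", "first", "only" and "open" are said of these compounds alone.

The series shares one core and varies in the aryl group and in the oxygen substituent. Compound 1 `CC(=O)Oc1ccc2cc(-n3cc(-c4ccccc4)nn3)c(=O)oc2c1C` carries a phenyl group and an acetoxy group, and in a functional assay on MCF7 cells (Homo sapiens) for antiproliferative activity (on this read-out lower numbers stand for stronger inhibition and higher numbers for weaker inhibition), compound 1 gives 40800 nM. Compound 2 `CC(=O)Oc1ccc2cc(-n3cc(-c4ccc(F)cc4F)nn3)c(=O)oc2c1C` replaces the phenyl with 2,4-difluorophenyl. In this assay compound 2 reaches only > 100000 nM, which is a limit of the assay rather than a number. Within the data shown here, this is the single measured step, an at least 2.4-fold higher number from compound 1 to compound 2 (0.38 log units; beyond the scatter). Compound 3 `Cc1c(O)ccc2cc(-n3cc(-c4ccc(N(C)C)cc4)nn3)c(=O)oc12` bears a dimethylamino-substituted phenyl and a free hydroxy group. In this assay, from the compounds shown here alone, compound 3 likewise stands at > 100000 nM, a limit only; it is one of the two values sitting at the limit of > 100000 nM in this assay, at which 2 of the 3 values shown sit, so its true number is unknown.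

Compound 4 `CC(=O)Oc1ccc2cc(-n3cc(-c4ccc(N(C)C)cc4)nn3)c(=O)oc2c1C` differs from compound 3 by acetyl in place of hydrogen on an oxygen on an aromatic ring. Among the measured compounds shown here, no measured step covers this acetylation; the only measured step concerns the aryl group, not the oxygen, so it gives no direct guidance. Compound 1, which carries the acetoxy group together with a plain phenyl, gives 40800 nM, still very weak. Compound 4 is therefore expected to stay near the limit, at an estimated 100000 nM with a range of 30000 nM to 300000 nM. This estimate means a step of a number no higher from compound 3 to compound 4 (the limit leaves the size open), expected to lie within the scatter, with a good chance that only a limit is reported.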

Compound 4, half-maximal inhibitory concentration: > 100000 nM
Compound 4 gave a limit, no number; the forecaster's own chance of this, stated with the estimate: 60%; the middle value lies on the limit itself.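

Dimethylamino in place of hydrogen on an aromatic carbon, with the acetoxy group kept, gives an at least 2.4-fold higher number from compound 1 to compound 4 (0.38 log units; beyond the scatter) in this assay. Two different changes on the phenyl group, the 2,4-difluorophenyl of compound 2 and the 4-(dimethylamino)phenyl of compound 4, now each lead away from compound 1, the only compound shown with a number rather than a limit. The steps from compound 3 to compound 4 and from compound 2 to compound 4 cannot be read, because both ends of each are limits: the limit of > 100000 nM in this assay, at which 3 of the 4 values shown sit.

From the compounds shown here alone, the effect of going from hydroxy to acetoxy therefore stays open, as does how far compound 2, compound 3 and compound 4 actually lie beyond the limit. Also open, going by these compounds, is whether a methoxy group or a chlorine atom on the phenyl, or a longer acyl chain on the oxygen, would give a lower number than compound 1 with its 40800 nM.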